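Chloro added to the trifluoromethylphenyl of compound 1

The compounds below may be only part of what the source reports. "The series", "measured", "known", "first", "only" and "open" are said of these compounds alone.

Measured so far in a functional assay on SK-OV-3 cells (Homo sapiens) for inhibition, read by sulforhodamine B assay, with a stated time of 48 h; a lower number here means a stronger inhibitor of growth, a higher number a weaker inhibitor of growth:
compound 1 `O=C(Nc1cccc(-n2cc(-c3ccncc3)c(-c3ccc(Cl)c(O)c3)n2)c1)Nc1cccc(C(F)(F)F)c1` gives 4970 nM
compound 2 `COc1cc(-c2nn(-c3cccc(NC(=O)Nc4cccc(C(F)(F)F)c4)c3)cc2-c2ccncc2)ccc1Cl` gives 2020 nM
compound 3 `O=C(Nc1cccc(-n2cc(-c3ccncc3)c(-c3ccc(Cl)c(O)c3)n2)c1)Nc1cc(C(F)(F)F)cc(C(F)(F)F)c1` gives 1350 nM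

Compound 1 stands at the highest of the three numbers in this assay; the step to compound 2 is the nearest, that to compound 3 the furthest, and both lie beyond the scatter.

Compound 4 `O=C(Nc1cccc(-n2cc(-c3ccncc3)c(-c3ccc(Cl)c(O)c3)n2)c1)Nc1ccc(Cl)c(C(F)(F)F)c1` is not yet measured. It differs from compound 1 by chloro in place of hydrogen on an aromatic carbon, on the same ring where compound 3 carries its second trifluoromethyl.

Within the data shown here, two measured steps bear on this. a 3.7-fold lower number from compound 1 to compound 3 (0.57 log units; beyond the scatter): an added group on the trifluoromethylphenyl ring lowered the number modestly. a 2.5-fold lower number from compound 1 to compound 2 (0.39 log units; beyond the scatter): a change elsewhere in the molecule also lowered the number modestly. Both steps went the same way, and the change here again adds one heavy atom on that ring. A modest lowering in this assay is therefore expected, smaller than or about the size of the step to compound 3, with a fair chance it stays within the scatter.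

The estimate for compound 4 is 1800 nM in this assay, with a range from 700 nM to 4500 nM. This means an expected step of a 2.8-fold lower number from compound 1 to compound 4 (0.44 log units; beyond the scatter).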

Compound 4, concentration for 50% growth inhibition: 1340 nM
The estimate for compound 4 lay 1.3-fold (0.13 log units) above the measured number; low and high end bracket the measured number.
By their numbers in this assay, from the lowest: compounds 4, 3 and 2 (each within the scatter of the next); then compound 1.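

In this assay the position on the 3-(trifluoromethyl)phenyl ring that lies ortho to a trifluoromethyl group and para to a large group takes chloro in place of hydrogen, with a 3.7-fold lower number from compound 1 to compound 4 (0.57 log units; beyond the scatter) for the change to 4-chloro-3-(trifluoromethyl)phenyl. Compound 3 alone had previously shown an addition on this ring, with a 3.7-fold lower number from compound 1 to compound 3 (0.57 log units; beyond the scatter) for a second trifluoromethyl; a single chlorine atom now gives a step of the same printed size, and the numbers of compound 3 and compound 4 lie within the scatter of each other, so among these compounds the lowering is not tied to trifluoromethyl as the entering group. Nothing in the data shown accounts for the size of this step.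

On these data alone, whether fluoro, methyl, an amine or a carboxylic acid at this position would give a similar step remains open. Also open, as far as these compounds go, is whether this chloro step would add to a 2.5-fold lower number from compound 1 to compound 2 (0.39 log units; beyond the scatter) in a compound carrying both changes, and whether the lower numbers reflect anything beyond growth inhibition in these cells.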